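The source may report more compounds than this note shows. Statements on the series, on what has been measured and on what is new or still open speak of the compounds shown alone.

Measured so far:
compound 1 `COc1ccc(C(=O)Nc2cccc(-c3oc4cc(-c5ccc(F)cc5)ccc4c(=O)c3O)c2)cc1` — 5490 nM
compound 2 `Cc1ccc(C(=O)Nc2cccc(-c3oc4cc(-c5ccc(F)cc5)ccc4c(=O)c3O)c2)cc1` — 7110 nM
compound 3 `Cc1cc(C(=O)Nc2cccc(-c3oc4cc(-c5ccc(F)cc5)ccc4c(=O)c3O)c2)ccc1F` — 5420 nM

All three values come from a functional assay on HCC1937 cells (Homo sapiens) for antiproliferative activity, read by CCK-8 assay, with a stated time of 72 h; on this read-out higher numbers stand for weaker inhibition and lower numbers for stronger inhibition. Compound 2 holds the highest number of the three, but its steps to both neighbours stay within the scatter: a 1.3-fold higher number from compound 1 to compound 2 (0.11 log units; within the scatter) and a 1.3-fold lower number from compound 2 to compound 3 (0.12 log units; within the scatter). The remaining step, a 1.0-fold lower number from compound 1 to compound 3 (0.01 log units; within the scatter), is likewise within the scatter, so on these numbers the three compounds cannot be told apart.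

Compound 4 `Cc1cc(C)cc(C(=O)Nc2cccc(-c3oc4cc(-c5ccc(F)cc5)ccc4c(=O)c3O)c2)c1` is not yet measured. Its difference from compound 2: 3,5-dimethylphenyl in place of 4-methylphenyl on a carbonyl carbon. Both measured steps that alter the aryl group on the carbonyl carbon bear on this. a 1.3-fold higher number from compound 1 to compound 2 (0.11 log units; within the scatter) exchanged one substituent of that aryl group and left the number within the scatter; a 1.3-fold lower number from compound 2 to compound 3 (0.12 log units; within the scatter) brought a second substituent onto the aryl group and again stayed within the scatter. Among the compounds with values here, no measured compound carries two methyl groups on that aryl group, so the new arrangement is not covered directly. On the strength of these steps, the expected step is a 1.0-fold lower number from compound 2 to compound 4 (0.01 log units; within the scatter), with no shift beyond the scatter expected in either direction. Compound 4 is therefore estimated at 7000 nM, in the range 3500 nM to 14000 nM.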

Compound 4, half-maximal inhibitory concentration: 4860 nM
Estimate against measurement, compound 4: 1.4-fold (0.16 log units) above, and the stated range covers the measured number.
By their numbers in this assay, from the lowest: compounds 4, 3, 1 and 2 (each within the scatter of the next).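

Setting 3,5-dimethylphenyl in place of 4-methylphenyl on the carbonyl carbon gives a 1.5-fold lower number from compound 2 to compound 4 (0.17 log units; within the scatter) in this assay and is the first listed change that puts two methyl groups on this aryl group. Compared with the two other aryl groups, the same group gives a 1.1-fold lower number from compound 3 to compound 4 (0.05 log units; within the scatter) and a 1.1-fold lower number from compound 1 to compound 4 (0.05 log units; within the scatter), so it cannot be separated from the 4-fluoro-3-methylphenyl of compound 3 or the 4-methoxyphenyl of compound 1. This position therefore accepts a second methyl group with no change that can be told from the scatter, and nothing at hand explains this flat response.

On these data alone, all four groups at this position are phenyl rings bearing methyl, methoxy or fluoro substituents, so it remains open whether an amine, a carboxylic acid or a longer alkyl chain on the ring would move the number beyond the scatter. As far as these compounds go, it is also open whether a pyridine ring in place of the phenyl ring, or a change in the amide link to the shared core, would separate compounds that these four values cannot.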